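Working notes: replacing the 4-methylpiperazin-1-yl group in compound 3

The source may hold more compounds than are shown below. What is called first, only, known or untested is meant among the compounds shown, and "the series" means these compounds.

Measured in a functional assay on SW480 cells (Homo sapiens) for antiproliferative activity, read by MTT assay, with a stated time of 48 h; on this read-out lower numbers stand for stronger inhibition and higher numbers for weaker inhibition:
Compound 1 `CC(=O)OC/C1=C/C[C@](C)(CCC=C(C)C)/C=C/[C@@H](OC(=O)C=C(C)C)[C@](C)(O)/C=C/C1=O`: 2950 nM
Compound 2 `CC(C)=CCC[C@]1(C)/C=C/[C@@H](OC(=O)C=C(C)C)[C@](C)(O)/C=C/C(=O)/C(CN(C(C)C)C(C)C)=C\C1`: 750 nM
Compound 3 `CC(C)=CCC[C@]1(C)/C=C/[C@@H](OC(=O)C=C(C)C)[C@](C)(O)/C=C/C(=O)/C(CN2CCN(C)CC2)=C\C1`: 800 nM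

Compound 3, at 800 nM, sits level with the diisopropylamino member: a 1.1-fold higher number from compound 2 to compound 3 (0.03 log units; within the scatter). Among the measured compounds shown here, the only number clearly apart from it belongs to the acetoxy member: a 3.7-fold lower number from compound 1 to compound 3 (0.57 log units; beyond the scatter).

The next member is compound 4 `CC(C)=CCC[C@]1(C)/C=C/[C@@H](OC(=O)C=C(C)C)[C@](C)(O)/C=C/C(=O)/C(C[Si](C)(C)C(C)(C)C)=C\C1`, and the change is a group of 7 heavy atoms (6 carbon, 1 silicon; no ring) in place of a group of 7 heavy atoms (5 carbon, 2 nitrogen; one six-membered non-aromatic ring with 2 hetero atoms), on a saturated chain carbon bound to a double-bonded ring carbon. The place is on a saturated chain carbon bound to a double-bonded ring carbon, the same place varied in all three measured compounds.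

For the measured compounds named here, two measured steps bear on it from the acetoxy side: a 3.9-fold lower number from compound 1 to compound 2 (0.59 log units; beyond the scatter) and a 3.7-fold lower number from compound 1 to compound 3 (0.57 log units; beyond the scatter). Both were modest and nearly equal in size. Exchanging one nitrogen group for the other, as in a 1.1-fold higher number from compound 2 to compound 3 (0.03 log units; within the scatter), moved nothing beyond the scatter. Going by the values given here, no measured compound carries a group without nitrogen other than compound 1, and none carries silicon, so these steps guide the estimate only loosely.

A modest step to a higher number in this assay is expected, partway back towards compound 1 at 2950 nM. The expected step is a 2.3-fold higher number from compound 3 to compound 4 (0.35 log units; beyond the scatter).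

For compound 4 the estimated value is 1800 nM, with an expected range of 600 nM to 5000 nM.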

Compound 4, half-maximal inhibitory concentration: 3350 nM
Compound 4: middle estimate off by 1.9-fold (0.27 log units), on the low side, within the range that was stated.
By their numbers in this assay, from the lowest: compounds 2 and 3 (each within the scatter of the next); then compounds 1 and 4 (each within the scatter of the next).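

In this assay the silicon group, which carries no nitrogen, stands clearly apart from both nitrogen groups, with a 4.2-fold higher number from compound 3 to compound 4 (0.62 log units; beyond the scatter) and a 4.5-fold higher number from compound 2 to compound 4 (0.65 log units; beyond the scatter), so the split seen so far at this saturated chain carbon does not depend on which of the two nitrogen groups is left. Against the acetoxy member the same group gives a 1.1-fold higher number from compound 1 to compound 4 (0.06 log units; within the scatter), which places the two nitrogen-free groups level even though they differ in heavy atom count, while compounds 2, 3 and 4, with the same count of 7 heavy atoms in the varied group, do not all agree, so that count alone does not sort these four compounds. Nothing available explains this split.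

Whether nitrogen itself marks the line remains open, since the four compounds cannot separate it from the other differences among these groups. A morpholin-4-yl or dimethylamino group would test how widely the level of compounds 2 and 3 holds, and an all-carbon 2,2-dimethylpropyl chain or a carboxylic acid would test how widely the level of compounds 1 and 4 holds.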